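Methyl in place of 1-hydroxyethyl: a cytotoxicity working note

The source may report more compounds than this note shows. Statements on the series, on what has been measured and on what is new or still open speak of the compounds shown alone.

In an ADME assay on T29 cells (Homo sapiens) for cytotoxicity, read by sulforhodamine B assay, with a stated time of 3 days (a lower number here means a stronger inhibitor, a higher number a weaker inhibitor), two compounds have been run, and neither gave a number. Compound 1 `O=Cc1cn(Cc2ccc(Cl)cc2Cl)c2ccccc12` reads > 31600 nM as a limit of the assay. Compound 2 `CC(O)c1cn(Cc2ccc(Cl)cc2)c2ccccc12` reads > 31500 nM as a limit too. Compound 2 therefore stands with a limit only, and the same holds for compound 1. For the measured compounds named here, these two compounds differ in more than one place, so no single-change step is available to calibrate the next case.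

That case is compound 3 `Cc1cn(Cc2ccc(Cl)cc2)c2ccccc12` which remains unmeasured. The change methyl in place of 1-hydroxyethyl on an aromatic carbon puts methyl in place of 1-hydroxyethyl on an aromatic carbon, two ring bonds from the ring nitrogen. In this assay no step beyond the usual scatter is expected in either direction, and another limit is the likeliest report. That expectation rests on compound 2 with its > 31500 nM reading, which is a limit. The estimated change a number no higher from compound 2 to compound 3 (the limit leaves the size open) is expected to stay within the scatter. For compound 3 the estimate is 31500 nM with an expected range from 12000 nM to 60000 nM for this measurement.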

Compound 3, half-maximal inhibitory concentration: > 31600 nM
Compound 3: a limit, no number (the forecaster's own chance of this, stated with the estimate: 75%); at least 1.0-fold (0.00 log units) between middle value and limit.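

Compound 2 and compound 3 both read as limits in this assay, not as numbers, so no step can be read between them. The compounds shown leave open whether methyl in place of 1-hydroxyethyl on an aromatic carbon changes this read-out at all, and where any of the three compounds would give an actual number.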